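From One Methyl Group to Three

A few compounds are considered here, and "the series" means these few. Any claim that something is new, unique, unknown or untested is made for them only; others in the source may bear on it.

In a functional assay on MDA-MB-231 cells (Homo sapiens) for inhibition, read by CCK-8 assay, with a stated time of 48 h (on this read-out lower numbers stand for stronger inhibition of growth and higher numbers for weaker inhibition of growth), three compounds sharing one core have been measured. Compound 1 `Cc1ccccc1Nc1nc(Nc2ccc(N3CCN(C)CC3)cn2)ncc1Cl` gives 7470 nM, compound 2 `COc1ccc(CNc2nc(Nc3ccc(N4CCN(C)CC4)cn3)ncc2Cl)cc1` gives 14900 nM, and compound 3 `Cc1cccc(Nc2nc(Nc3ccc(N4CCN(C)CC4)cn3)ncc2Cl)c1` gives 5270 nM. Compound 3 thus sits level with compound 1 and clearly apart from compound 2.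

The next change replaces the 3-methylphenyl of compound 3 with 2,4,6-trimethylphenyl, on a nitrogen on an aromatic ring, giving compound 4 `Cc1cc(C)c(Nc2nc(Nc3ccc(N4CCN(C)CC4)cn3)ncc2Cl)c(C)c1`: 2,4,6-trimethylphenyl in place of 3-methylphenyl on a nitrogen on an aromatic ring.

The nearest evidence comes from compound 1 and compound 3, which differ only in where one methyl group sits on that ring. That change produced a 1.4-fold lower number from compound 1 to compound 3 (0.15 log units; within the scatter). The larger 2.8-fold lower number from compound 2 to compound 3 (0.45 log units; beyond the scatter) involves 4-methoxybenzyl, a different kind of group, so it bears less directly on this change. Going by the values given here, no measured compound carries three methyl groups on that ring, so the data offer no direct test and the uncertainty is wide.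

With only a small shift seen among the methylphenyl compounds, the expected result in this assay is a 1.4-fold higher number from compound 3 to compound 4 (0.15 log units; within the scatter), a small rise that is not expected to pass the scatter. Compound 4 is estimated at 7500 nM, with an expected range from 3000 nM to 18000 nM.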

Compound 4, concentration for 50% growth inhibition: 21000 nM
Beside the measured number, compound 4's estimate is 2.8-fold (0.45 log units) below it; measured number above the stated range.
By their numbers in this assay, from the lowest: compounds 3, 1, 2 and 4 (each within the scatter of the next, the first and the last beyond it).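

In this assay, shifting a single methyl group on the phenyl ring had stayed within the scatter, but the ring with three methyl groups gives a clear change at this nitrogen (a 4.0-fold higher number from compound 3 to compound 4 (0.60 log units; beyond the scatter)) and a similar one against the other single-methyl compound (a 2.8-fold higher number from compound 1 to compound 4 (0.45 log units; beyond the scatter)). So this position does respond to the group it carries, and among these three methylphenyl compounds, more methyl groups go with weaker inhibition of growth, while the one compound outside that series cannot be placed apart from compound 4 (a 1.4-fold higher number from compound 2 to compound 4 (0.15 log units; within the scatter)). Nothing available explains why the trimethylphenyl compound behaves this way.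

The compounds shown leave open whether a phenyl ring with two methyl groups would read closer to compound 3 or to compound 4, and so whether the change builds with each added methyl group or depends on one particular methyl group. They also leave open how this position would respond to a ring carrying something other than carbon groups, such as an amine or a carboxylic acid.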